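Replacing the 2-oxoimidazolidin-1-yl group of compound 2

A few compounds are considered here, and "the series" means these few. Any claim that something is new, unique, unknown or untested is made for them only; others in the source may bear on it.

Going by the values given here, in a functional assay on CHO cells for antagonist activity at prostaglandin E2 receptor EP3 subtype (Homo sapiens), read by cAMP accumulation (on this read-out lower numbers stand for stronger inhibition and higher numbers for weaker inhibition), compound 1 `CC(C)C(Cc1ncc[nH]1)c1ccc(-c2ccc3cccc(F)c3c2)[nH]c1=O` gives 76 nM, and compound 2 `CC(C)C(c1ccc(-c2ccc3cccc(F)c3c2)[nH]c1=O)N1CCNC1=O` gives 28 nM, the lowest of the two numbers measured so far; the one step of a 2.7-fold lower number from compound 1 to compound 2 (0.43 log units; beyond the scatter) separates them and is the only measured step. Compound 3 `CC(C)C(/C=C1\CCNC1=O)c1ccc(-c2ccc3cccc(F)c3c2)[nH]c1=O` differs from compound 2 by a group of 7 heavy atoms (5 carbon, 1 nitrogen, 1 oxygen; one five-membered non-aromatic ring with 1 hetero atom) in place of a group of 6 heavy atoms (3 carbon, 2 nitrogen, 1 oxygen; one five-membered non-aromatic ring with 2 hetero atoms), on a saturated chain carbon bound to an aromatic carbon and a saturated chain carbon. That single step touches the same saturated chain carbon but swaps in a different group, so it bears on compound 3 only loosely. The expectation for compound 3 is a step of a 2.0-fold higher number from compound 2 to compound 3 (0.29 log units; within the scatter), toward a modestly higher number. Compound 3 is therefore estimated at 55 nM, with a range from 15 nM to 200 nM.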

Compound 3, half-maximal inhibitory concentration: 8.7 nM
Compound 3: the middle estimate sits 6.3-fold (0.80 log units) above what was measured; measured number below the stated range.
By their numbers in this assay, from the lowest: compound 3; then compound 2; then compound 1.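

In this assay, the group on this saturated chain carbon need not carry a second ring hetero atom: the five-membered non-aromatic ring with 1 hetero atom gives a 3.2-fold lower number from compound 2 to compound 3 (0.51 log units; beyond the scatter). The wider gap, an 8.7-fold lower number from compound 1 to compound 3 (0.94 log units; beyond the scatter), leaves the lowest number of the three at this position, with both steps beyond the scatter. No measurement available here accounts for the gain.

Open, on these data alone, is whether the ring hetero atom count or the added double bond carries the step, since both change together. Also open, as far as these compounds go, is how an amine or a carboxylic acid on the same carbon would read.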